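The source may report more compounds than this note shows. Statements on the series, on what has been measured and on what is new or still open speak of the compounds shown alone.

For the measured compounds named here, in an ADME assay on N2a cells (Mus musculus) for cytotoxicity, read by MTT assay (a lower number here means a stronger inhibitor, a higher number a weaker inhibitor), compound 1 `C#CC[C@@H]1C[C@H](n2cccc2C(C)=O)C(=O)O1` gives 121000 nM, the only actual number so far. Compound 2 `C#CC[C@H]1C[C@H](n2cccc2C(C)=O)C(=O)O1` gives > 100000 nM, and this value is a limit. Going by the values given here, the one measured step is a step that the limit leaves unreadable from compound 1 to compound 2. It reflects the fact that compounds 1 and 2 differ only in the configuration as drawn and leaves the acetyl group untouched, so it offers no size to carry forward.

Compound 3 `C#CC[C@@H]1C[C@H](n2cccc2C(=O)CC)C(=O)O1` differs from compound 1 by methyl in place of hydrogen on a saturated chain carbon bound to a carbonyl carbon, which turns acetyl to propanoyl. Among the compounds with values here, no measured step covers this change, and the data give no direction for it. The expectation therefore rests on compound 1 at 121000 nM alone, with no step beyond the scatter foreseen. The expected change is a 1.1-fold lower number from compound 1 to compound 3 (0.04 log units; within the scatter). Compound 3 is estimated at 110000 nM, with an expected range of 50000 nM to 250000 nM. A read-out as a limit alone would be no surprise.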

Compound 3, half-maximal inhibitory concentration: 40600 nM
Compound 3: middle estimate off by 2.7-fold (0.43 log units), on the high side, outside the stated range (below it).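

In this assay, for the compounds shown here, the change from acetyl to propanoyl gives a 3.0-fold lower number from compound 1 to compound 3 (0.47 log units; beyond the scatter) and is the first readable step. It shows that the saturated chain carbon bound to a carbonyl carbon is not a silent place in this assay: one added methyl moves the number beyond the scatter, towards a lower value. The finding rests on this single pair, and nothing measured here bears on the cause of the step.

From the compounds shown here alone, the step between the two configurations cannot be read, so it remains open whether the same methyl change would have a similar effect in the configuration of compound 2. Going by these compounds, it is also open whether a longer chain such as butanoyl, or an amine at this carbon, would take the number further in the same direction.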